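Adding a fluoro to compound 2

The compounds below may be only part of what the source reports. "The series", "measured", "known", "first", "only" and "open" are said of these compounds alone.

Measured so far in a functional assay on A549 cells (Homo sapiens) for inhibition, read by MTT assay, with a stated time of 72 h; on this read-out lower numbers stand for stronger inhibition and higher numbers for weaker inhibition:
Compound 1 `O=C1C=CC(O)(c2cc3ccc(F)cc3n2S(=O)(=O)c2ccccc2)C=C1` gives 500 nM
Compound 2 `COC(=O)CCc1ccc(S(=O)(=O)n2c(C3(O)C=CC(=O)C=C3)cc3ccccc32)cc1` gives 500 nM

Among the compounds with values here, compound 2 stands level with compound 1, the only other compound measured, and the two agree within the scatter. Compound 3 `COC(=O)CCc1ccc(S(=O)(=O)n2c(C3(O)C=CC(=O)C=C3)cc3ccc(F)cc32)cc1` matches compound 2 except in one place, with fluoro in place of hydrogen on an aromatic carbon. Within the data shown here, compound 1 also carries a fluoro on the shared core but lacks the methyl ester chain of compound 2, so no measured pair shows the fluoro alone. With compound 1 at 500 nM and compound 2 at 500 nM, no step beyond the scatter is expected in this assay. The estimated step of a 1.1-fold lower number from compound 2 to compound 3 (0.05 log units; within the scatter) is therefore expected to be small. For compound 3 the expected value is 450 nM, with an estimated range from 180 nM to 1100 nM.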

Compound 3, half-maximal inhibitory concentration: 500 nM
The estimate for compound 3 lay 1.1-fold (0.05 log units) below the measured number, and the stated range covers the measured number.
By their numbers in this assay, from the lowest: compounds 1, 2 and 3 (each within the scatter of the next).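

In this assay, within the data shown here, the fluoro in place of hydrogen on an aromatic carbon gives no change at the digits printed from compound 2 to compound 3 (within the scatter) and so provides the first measured pair that isolates this change, at the place meta to a fused ring and para to a fused ring. Compound 3 also completes a second pair, where adding the methyl ester chain to the fluoro-bearing shared core gives no change at the digits printed from compound 1 to compound 3 (within the scatter). No measured evidence bears on why these numbers stay level.

From the compounds shown here alone, whether a chloro or a methoxy group at this same place would move the number beyond the scatter remains open. So does the outcome of replacing the methyl ester of the chain with a carboxylic acid or an amide.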